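Kinetic solubility of the series: compound 2 to compound 4

The source may report more compounds than this note shows. Statements on the series, on what has been measured and on what is new or still open speak of the compounds shown alone.

Measured in one read-out (a physicochemical assay for solubility, measured as kinetic solubility; on this read-out lower numbers stand for lower solubility and higher numbers for higher solubility):
compound 1 `COC(c1cc(Cl)c2c(c1Cl)C(=O)N(Cc1c(C)cc(C)[nH]c1=O)CC2)C1CCOC1` gives 415000 nM; 457000 nM; 439000 nM; 436000 nM (4 entries)
compound 2 `Cc1cc(C)c(CN2CCc3c(Cl)cc([C@@H](CO)[C@@H]4CCOC4)c(Cl)c3C2=O)c(=O)[nH]1` gives 537000 nM
compound 3 `CCOC(c1cc(Cl)c2c(c1Cl)C(=O)N(Cc1c(C)cc(C)[nH]c1=O)CC2)C1CS(=O)(=O)C1` gives 453000 nM; 446000 nM (2 entries)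

Among the compounds with values here, compound 2 stands at 537000 nM as its only number, and its further entries give no single number. That value and those of compound 1 (415000 nM; 457000 nM; 439000 nM; 436000 nM (4 entries)) and compound 3 (453000 nM; 446000 nM (2 entries)) lie within the usual scatter of one another.

Compound 4 `Cc1cc(C)c(CN2CCc3c(Cl)cc([C@@H](C)CO)c(Cl)c3C2=O)c(=O)[nH]1` is compound 2 with one change (a group of 4 heavy atoms (3 carbon, 1 oxygen; no ring) in place of a group of 8 heavy atoms (6 carbon, 2 oxygen; one five-membered non-aromatic ring with 1 hetero atom), on an aromatic carbon): 1-(hydroxymethyl)ethyl, a group of 4 heavy atoms with no ring, takes the place of a group of 8 heavy atoms with one five-membered non-aromatic ring, on an aromatic carbon.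

Within the data shown here, no step between measured compounds is available to size this change. The three measured values sit close together, so no change beyond the scatter is expected in this assay, and no direction can be argued. The estimated size of the change is small (a 1.1-fold lower number from compound 2 to compound 4 (0.05 log units; within the scatter)). For compound 4 the expected value is 480000 nM (range 300000 nM to 700000 nM).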

Compound 4, solubility: 143000 nM
Beside the measured number, compound 4's estimate is 3.4-fold (0.53 log units) above it; measured number below the stated range.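

In this assay, the position on the aromatic carbon ortho to a chloro group proves sensitive: 1-(hydroxymethyl)ethyl, with no ring, in place of the group with one five-membered non-aromatic ring gives a 3.8-fold lower number from compound 2 to compound 4 (0.57 log units; beyond the scatter). The earlier compounds shown here all carry a ring in the group at this position and lie within the scatter of one another, so they gave no sign of such a step. Repeat entries in this series stay close together, which supports reading the step as a real difference, although compound 4 has a single entry: the several entries of compound 1 in this assay, 415000 nM; 457000 nM; 439000 nM; 436000 nM (4 entries)

A second series of repeats agrees as closely: the several entries of compound 3 in this assay, 453000 nM; 446000 nM (2 entries)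

Within the data shown here, the single step cannot separate the loss of the ring from the loss of heavy atoms. On these data alone, how an amine or a carboxylic acid on the 1-(hydroxymethyl)ethyl chain would read here remains open.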